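The source may hold more compounds than are shown below. What is called first, only, known or untested is meant among the compounds shown, and "the series" means these compounds.

Among the compounds with values here, in a functional assay (aorta) for inhibition, with Homo sapiens as the target, using microsomes, in the presence of a further agent that is not named here (on this read-out lower numbers stand for stronger inhibition and higher numbers for weaker inhibition), compound 1 (`CCOC(=O)/C(C)=C\c1ccc(Cc2cccnc2)n1C(C)C`) gives 32000 nM as the highest number of the three measured so far, which makes it the weakest inhibitor among them. Compound 3 (`CCOC(=O)/C(C)=C\c1ccc(Cn2ccnc2)[nH]1`) gives 8100 nM as the nearest value and compound 2 (`CCOC(=O)/C(C)=C/c1cc(Cn2ccnc2)n(C)c1`) gives 1800 nM as the furthest, and both gaps lie beyond the scatter. Within the data shown here, neither differs from compound 1 in one place only, so no measured step bears directly on the change at hand.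

Compound 4 (`CCOC(=O)/C(C)=C\c1ccc(Cc2cccnc2)n1CC`) is still unmeasured. Its change from compound 1 reads hydrogen in place of methyl on a saturated chain carbon bound to an aromatic nitrogen and a saturated chain carbon and amounts to isopropyl to ethyl. Among the measured compounds shown here, with no direct precedent, only a small step to a lower number is expected in this assay and it may well stay within the scatter. The expected move is a 1.6-fold lower number from compound 1 to compound 4 (0.20 log units; within the scatter) on this estimate. For compound 4 the estimated value is 20000 nM with an expected range from 8000 nM to 60000 nM overall.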

Compound 4, half-maximal inhibitory concentration: 14000 nM
The estimate for compound 4 lay 1.4-fold (0.15 log units) above the measured number; low and high end bracket the measured number.
By their numbers in this assay, from the lowest: compound 2; then compounds 3 and 4 (each within the scatter of the next); then compound 1.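

In this assay, within the data shown here, the change from isopropyl to ethyl gives a 2.3-fold lower number from compound 1 to compound 4 (0.36 log units; beyond the scatter) as a modest step beyond the scatter, and this is the first comparison that differs in one place only. Among these compounds, it shows that this position is sensitive to a small edit: hydrogen in place of methyl on a saturated chain carbon bound to an aromatic nitrogen and a saturated chain carbon is enough to shift the read-out, which the earlier compounds could not show. No supporting measurement is available to explain this step.

On these data alone, whether the number keeps falling with further changes at this place remains open, for example with cyclopropyl, a longer chain such as butyl, or a chain ending in an amine. A single step also leaves open whether the same change would move the number similarly in other compounds of the series.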